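The compounds below may be only part of what the source reports. "The series", "measured", "known", "first", "only" and "open" are said of these compounds alone.

Measured compounds in an ADME assay on microsomes from liver (Homo sapiens) for metabolic stability, read by LC-MS, with NADPH named in the record, with a stated time of 60 min, tested at 1 uM, in the absence of a further agent; on this read-out higher numbers stand for a more stable compound and lower numbers for a less stable compound:
compound 1 `COc1ccc(-n2c(C)nc3c(N4CC[C@@H](NC(C)=O)C4)nc(C)nc32)cc1OC` — > 95%
compound 2 `COc1ccc(-c2scc3c(N4CC[C@@H](NC(C)=O)C4)nc(C)nc23)cc1OC` — > 95%
compound 3 `COc1ccc(-c2c(C)nc3c(N4CC[C@@H](NC(=O)COc5ccccc5)C4)cc(C)nn23)cc1OC` — > 95%

Each of these three values is a limit of the assay and not a number. For compound 1 the value > 95% is such a limit. For compound 2 the value > 95% is such a limit. For compound 3 the value > 95% is likewise a limit, so compound 3 stands at the same limit as the other two, and no order among the three can be read from these results; all that is known is the limit of > 95% in this assay, at which 3 of the 3 values shown sit. Among the measured compounds shown here, no pair of measured compounds differs in one place, so no measured step is available.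

Compound 4 `COc1ccc(-c2c(C)nc3c(N4CC[C@@H](OC(C)=O)C4)cc(C)nn23)cc1OC` has not yet been measured. It differs from compound 3 in one place: acetoxy in place of ((phenoxymethyl)carbonyl)amino on a saturated ring carbon. Every measured compound sits at the limit of the assay. Compound 3 gives > 95%, which is such a limit. For the measured compounds named here, the data give no measured step on which to size this change. Compound 4 is therefore expected to remain stable, with an estimate of 85% and a range from 60% to 97%. The expected step of a number at least 10 percentage points lower from compound 3 to compound 4 (that floor lies within the scatter) is small and, if present, downward, but may well lie within the scatter.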

Compound 4, percent of the compound remaining: > 95%
Compound 4 gave a limit, no number; the forecaster's own chance of this, stated with the estimate: 45%; middle value at least 10 percentage points away from the limit.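

In this assay compound 4 gives > 95%, which is a limit of the assay and not a number. Compound 3 also stands at a limit, so no step can be read between compound 3 and compound 4. The compounds shown leave open any order of stability among them, as every value is a limit: the limit of > 95% in this assay, at which 4 of the 4 values shown sit.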